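Series notes: methylsulfamoyl in place of fluoro

A few compounds are considered here, and "the series" means these few. Any claim that something is new, unique, unknown or untested is made for them only; others in the source may bear on it.

Measured so far:
compound 1 `Oc1cccc2cc(-c3ccc(F)cc3)ccc12`: < 10%
compound 2 `Oc1cccc2cc(-c3ccncc3)ccc12`: < 10%

In an assay for binding affinity to 17-beta-hydroxysteroid dehydrogenase type 1 (Homo sapiens), with a stated time of 20 min, tested at 1 uM (a higher number here means more inhibition at the concentration tested (going by the name of the read-out), a lower number less inhibition), compound 1 gives only a limit of the assay, < 10%. Compound 2 likewise gives a limit, < 10%. Both values rest at the limit of < 10% in this assay, at which 2 of the 2 values shown sit. Compound 3 `CNS(=O)(=O)c1ccc(-c2ccc3c(O)cccc3c2)cc1` is not yet measured; it differs from compound 1 by methylsulfamoyl in place of fluoro on an aromatic carbon. Going by the values given here, no step between two measured compounds exists here, so in this assay a change beyond the scatter is uncertain; a small rise or none is expected. Compound 3 is expected at 15% (0% to 45%), an estimated step of a number at least 5 percentage points higher from compound 1 to compound 3 (that floor lies within the scatter) in this assay.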

Compound 3, a percentage reported as inhibition, at one concentration (the size of the read-out at that concentration, not a potency): 12%
The estimate for compound 3 lay 3 percentage points above the measured number; low and high end bracket the measured number.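

In this assay the change at this position, para to a large group, gives a number at least 2 percentage points higher from compound 1 to compound 3 (that floor lies within the scatter). The position therefore accepts methylsulfamoyl, a group of five heavy atoms with a hydrogen-bond donor, without a shift that can be told from the scatter. The value of compound 1, < 10%, is a limit of the assay, so the step has only a floor, and the series still sits largely at that limit: the limit of < 10% in this assay, at which 2 of the 3 values shown sit.

Open, from the compounds shown here alone, is whether an amine or a carboxylic acid here would move the read-out beyond the scatter. Also open, going by these compounds, is what a longer chain in place of the methyl on methylsulfamoyl would do.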